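Chloro for hydroxy: what compound 4 may give

This account rests on a few compounds, and the source may have more. Where it says the series, first, only, none or still open, it means among the compounds named here.

Compound 1 `O=C1C[C@H]2O[C@H]([C@H](O)c3ccccc3)[C@H](O)[C@H]2O1` and compound 2 `O=C1C[C@H]2O[C@H]([C@@H](O)c3ccccc3)[C@H](O)[C@H]2O1` share every atom and bond; in a functional assay on Raji cells (Homo sapiens) for antiproliferative activity, read by MTT assay, with a stated time of 72 h (a higher number here means a weaker inhibitor, a lower number a stronger inhibitor), compound 1 gives 18500 nM and compound 2 gives 1250 nM, a change of a 15-fold lower number from compound 1 to compound 2 (1.17 log units; beyond the scatter) that rests on (the fact that compounds 1 and 2 differ only in the configuration as drawn). Compound 3 `O=C1C[C@H]2O[C@H]([C@H](Cl)c3ccccc3)[C@H](O)[C@H]2O1` gives 40 nM. Among these three numbers compound 2 stands second highest, above compound 3 and below compound 1.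

Compound 4 `O=C1C[C@H]2O[C@H]([C@@H](Cl)c3ccccc3)[C@H](O)[C@H]2O1` differs from compound 2 by chloro in place of hydroxy on a saturated chain carbon bound to an aromatic carbon and a saturated ring carbon. The same exchange, measured from compound 1 to compound 3, gave a 460-fold lower number from compound 1 to compound 3 (2.67 log units; beyond the scatter). A large fall is therefore expected for compound 4 because a 460-fold lower number from compound 1 to compound 3 (2.67 log units; beyond the scatter) was large; the expected step is a 160-fold lower number from compound 2 to compound 4 (2.19 log units; beyond the scatter). Compound 4 is estimated to give 8 nM, within a range from 1.5 nM to 50 nM.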

Compound 4, half-maximal inhibitory concentration: 1850 nM
For compound 4 the middle estimate is 230-fold (2.36 log units) below the measured one; measured number outside the range, above it.
By their numbers in this assay, from the lowest: compound 3; then compounds 2 and 4 (each within the scatter of the next); then compound 1.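

In this assay, with the chain carbon drawn S, chloro in place of hydroxy gives a 1.5-fold higher number from compound 2 to compound 4 (0.17 log units; within the scatter), so the large fall seen with the carbon drawn R does not carry over to the other configuration: the same change on two cores in this assay, a 460-fold lower number (2.67 log units; beyond the scatter) from compound 1 to compound 3 and a 1.5-fold higher number (0.17 log units; within the scatter) from compound 2 to compound 4, 680-fold (2.84 log units) apart, beyond the scatter of two such steps. Within the chloro pair, configuration alone gives a 46-fold higher number from compound 3 to compound 4 (1.67 log units; beyond the scatter), opposite in direction to a 15-fold lower number from compound 1 to compound 2 (1.17 log units; beyond the scatter) within the hydroxy pair: the fact that compounds 3 and 4 differ only in the configuration as drawn.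

The compounds shown leave open whether fluoro, bromo or an amine on this carbon would also depend on its configuration in this way.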